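Trading a Trifluoromethylphenyl Amide for a Benzothiophene

The compounds below may be only part of what the source reports. "The series", "measured", "known", "first", "only" and "open" are said of these compounds alone.

Of the compounds shown here, three that share one core have been measured in a functional assay on A375P cells (Homo sapiens) for antiproliferative activity, read by MTT assay, with a stated time of 48 h; a higher number here means a weaker inhibitor, a lower number a stronger inhibitor. Compound 1 `Cc1cc(C(=O)Nc2cccc(-c3ccnc4c(N)cccc34)c2)ccc1Br` gives 9900 nM. Compound 2 `Nc1cccc2c(-c3cccc(NC(=O)c4cccc(C(F)(F)F)c4)c3)ccnc12` gives 7900 nM, the second highest of the three numbers. Compound 3 `Nc1cccc2c(-c3cccc(NC(=O)c4ccc(Cl)c(C(F)(F)F)c4)c3)ccnc12` gives 1400 nM, the lowest. Two steps connect them. a 1.3-fold lower number from compound 1 to compound 2 (0.10 log units; within the scatter) exchanges one whole aryl group on the carbonyl carbon for another and barely moves the number. a 5.6-fold lower number from compound 2 to compound 3 (0.75 log units; beyond the scatter) adds a single chloro and brings a modest gain in potency.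

Compound 4 `Nc1cccc2c(-c3cccc(NC(=O)c4cc5ccccc5s4)c3)ccnc12` has not yet been measured. It differs from compound 2 by 1-benzothiophen-2-yl in place of 3-(trifluoromethyl)phenyl on a carbonyl carbon. This is again an exchange of the entire group on the carbonyl carbon, so the step from compound 1 to compound 2 is the one that bears on it, and that step stayed within the scatter. The added chloro of compound 3 is a different kind of change and gives no direct guide. A step no larger than the scatter is therefore expected, written as a 1.2-fold lower number from compound 2 to compound 4 (0.08 log units; within the scatter). Compound 4 is estimated at 6500 nM, with a range from 2000 nM to 20000 nM.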

Compound 4, half-maximal inhibitory concentration: > 20000 nM
Compound 4 was reported as a limit (the forecaster's own chance of this, stated with the estimate: 10%); middle value at least 3.0-fold (0.48 log units) from the limit.
By their numbers in this assay, from the lowest: compound 3; then compounds 2 and 1 (each within the scatter of the next). At a limit, above all of these: compound 4.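

Exchanging a whole aryl group on the carbonyl carbon looked harmless from the first two compounds, but this position does respond to such a change: 1-benzothiophen-2-yl in place of 3-(trifluoromethyl)phenyl gives an at least 2.5-fold higher number from compound 2 to compound 4 (0.40 log units; beyond the scatter). In place of 4-bromo-3-methylphenyl, the same group gives an at least 2.0-fold higher number from compound 1 to compound 4 (0.30 log units; that floor lies within the scatter), so the comparison with compound 2 is the one that establishes the loss. On these data alone, compound 4 is known only as a limit, and the full size of both steps stays unknown: the limit of > 20000 nM in this assay, at which 1 of the 4 values shown sits.

As far as these compounds go, whether the loss follows the sulfur or the whole two-ring group stays open, and a naphthyl group, with both rings of carbon only, or a plain thienyl group would help separate the two. Also open, from the compounds shown here alone, is whether a chloro on the 1-benzothiophen-2-yl group would bring any gain like a 5.6-fold lower number from compound 2 to compound 3 (0.75 log units; beyond the scatter).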